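Swapping furan for thiophene on the central carbon

The source may report more compounds than this note shows. Statements on the series, on what has been measured and on what is new or still open speak of the compounds shown alone.

Measured compounds:
compound 1 `c1ccc(C(/N=C2\CCCCCN2)C2CCC2)cc1` with 14%
compound 2 `c1csc(C(/N=C2\CCCCCN2)C2CC2)c1` with 33%
compound 3 `c1ccc(C(/N=C2\CCCCCN2)c2ccco2)cc1` with 5%

In a functional assay on the whole organism (plasma, strain Sprague-Dawley) with Rattus norvegicus as the target, with a stated time of 2 h, at a dose of 12.5 mg/kg by the oral route (on this read-out lower numbers stand for a weaker effect and higher numbers for a stronger effect at the one dose given), compound 3 stands lowest of the three numbers. Its nearest neighbour is compound 1, whose value sits within the scatter of it, while compound 2 lies beyond the scatter above it. Going by the values given here, the only single-place step that exists here, a number 9 percentage points lower from compound 1 to compound 3 (within the scatter), changes the same carbon that is now in question and stays within the scatter.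

Compound 4 `c1ccc(C(/N=C2\CCCCCN2)c2cccs2)cc1` is the next compound. Its difference from compound 3 is thiophen-2-yl in place of furan-2-yl on a saturated chain carbon bound to an aromatic carbon and a double-bonded nitrogen. Among the compounds with values here, no measured step exchanges furan-2-yl for thiophen-2-yl, so no step of that kind can be read off. Within the data shown here, the one step on this carbon stayed within the scatter, so a change of similar size is expected here, with no clear direction. The expected step of a number 5 percentage points higher from compound 3 to compound 4 (within the scatter) is therefore small, and compound 4 is estimated at 10%, with a range from 0% to 28% in this assay.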

Compound 4, a percentage reported as inhibition, in the whole organism at one dose (the size of the read-out at that dose, not a potency): 23%
Beside the measured number, compound 4's estimate is 13 percentage points below it; measured number inside the range.
By their numbers in this assay, from the lowest: compounds 3, 1, 4 and 2 (each within the scatter of the next, the first and the last beyond it).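

In this assay, this carbon now gives its first step beyond the scatter: thiophen-2-yl in place of furan-2-yl, two aromatic rings that differ only in sulfur against oxygen, gives a number 18 percentage points higher from compound 3 to compound 4 (beyond the scatter). The other two changes on the same carbon stay inside the scatter: thiophen-2-yl in place of cyclobutyl gives a number 9 percentage points higher from compound 1 to compound 4 (within the scatter), and phenyl in place of cyclopropyl gives a number 10 percentage points lower from compound 2 to compound 4 (within the scatter). Nothing available explains why the sulfur ring and the oxygen ring read differently here.

The compounds shown leave open how an amine or a carboxylic acid on this carbon would read. They also leave open whether the rise seen with thiophen-2-yl would return if a cyclopropyl took the place of the phenyl shared by compound 3 and compound 4.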